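The source may report more compounds than this note shows. Statements on the series, on what has been measured and on what is new or still open speak of the compounds shown alone.

Compound 1 `O=C1/C(=C/c2ccccc2)CCC/C1=C\c1ccccc1[N+](=O)[O-]` is the starting point of this small series, and in a functional assay on HL-60 cells (Homo sapiens) for cytotoxicity, with a stated time of 24 h (a higher number here means that more compound is tolerated, a lower number that less compound is tolerated), compound 1 gives 3700 nM. Compound 2 `O=C1/C(=C/c2ccc(F)cc2)CCC/C1=C\c1ccccc1[N+](=O)[O-]` is compound 1 with fluoro in place of hydrogen on an aromatic carbon. In this assay compound 2 gives 3000 nM, which means a 1.2-fold lower number from compound 1 to compound 2 (0.09 log units; within the scatter), so the two numbers belong together. Compound 3 `O=C1/C(=C/c2ccccc2)CCC/C1=C\c1cccc([N+](=O)[O-])c1` is built from the same atoms as compound 1 joined differently; the difference between the two cores is not broken down here. In this assay compound 3 gives 3000 nM, agreeing with compound 2 at the digits reported. Compound 4 `O=C1/C(=C/c2ccc(F)cc2)CCC/C1=C\c1cccc([N+](=O)[O-])c1` has not been measured; it is compound 3 with fluoro in place of hydrogen on an aromatic carbon. The place of this change reads word for word as in the earlier pair, so it is the same change. On compound 1 that change produced a 1.2-fold lower number from compound 1 to compound 2 (0.09 log units; within the scatter), and the estimated step here, a 1.2-fold lower number from compound 3 to compound 4 (0.08 log units; within the scatter), rests on that single earlier observation. In this assay compound 4 is therefore expected to give 2500 nM, most likely between 1200 nM and 5500 nM.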

Compound 4, half-maximal cytotoxic concentration: 1000 nM
The estimate for compound 4 lay 2.5-fold (0.40 log units) above the measured number; the measured number lies below the stated range.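

In this assay, the swap of phenyl to 4-fluorophenyl on the core of compound 3 gives a 3.0-fold lower number from compound 3 to compound 4 (0.48 log units; beyond the scatter), a modest step that lies beyond the usual scatter when taken alone. Set beside the same swap on the core of compound 1, the new step cannot be told apart from the earlier one: the same change on two cores in this assay, a 1.2-fold lower number (0.09 log units; within the scatter) from compound 1 to compound 2 and a 3.0-fold lower number (0.48 log units; beyond the scatter) from compound 3 to compound 4, 2.4-fold (0.39 log units) apart, within the scatter of two such steps So nothing here shows that the two cores respond differently to this change, but with only two pairs, this neither proves that the step carries over unchanged nor rules out a truly larger step on the core of compound 3.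

The compounds shown leave open how an amine, a methoxy group or a carboxylic acid at this same place would compare with fluoro. They also leave open whether the swap of phenyl to 4-fluorophenyl would give a similar step on any core beyond these two.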